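The source may report more compounds than this note shows. Statements on the series, on what has been measured and on what is new or still open speak of the compounds shown alone.

Compound 2, `CCOc1ccc(-c2cccc(C)c2)cc1`, was tested in an assay on COS-7 cells for inhibition of patatin-like phospholipase domain-containing protein 2 (Mus musculus) (a lower number here means a stronger inhibitor, a higher number a weaker inhibitor), where it gives 70000 nM. Its companion compound 1, `CCOC(=O)c1cccc(-c2ccc(OCC)cc2)n1`, gives 60000 nM in this assay, so the two values sit within the scatter of one another and neither can be ranked above the other. Compound 3, `CCOc1ccc(-c2cccc(NC(=O)N(C)C)c2)cc1`, has not yet been measured. It differs from compound 2 by (dimethylcarbamoyl)amino in place of methyl on an aromatic carbon. Within the data shown here, no measured pair shows this change, so the size of the step can only be estimated; a step toward stronger inhibition beyond the scatter is expected, a 7.0-fold lower number from compound 2 to compound 3 (0.85 log units; beyond the scatter). Compound 3 is estimated at 10000 nM, within a range from 2000 nM to 50000 nM.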

Compound 3, half-maximal inhibitory concentration: 70000 nM
Compound 3: the middle estimate sits 7.0-fold (0.85 log units) below what was measured; the whole stated range lies below it.
By their numbers in this assay, from the lowest: compounds 1, 2 and 3 (each within the scatter of the next).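

Replacing methyl with (dimethylcarbamoyl)amino on this aromatic carbon gives no change at the digits printed from compound 2 to compound 3 (within the scatter) in this assay. The earlier compounds shown here did not show that this carbon can carry a group of 6 heavy atoms, including a hydrogen-bond donor and acceptor, in place of 1 heavy atom with no measurable shift. Nothing available explains this flat result.

As far as these compounds go, whether an amine or a carboxylic acid on this same carbon would move the number beyond the scatter remains open. So does the effect of a longer chain there.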